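The source may hold more compounds than are shown below. What is called first, only, known or untested is meant among the compounds shown, and "the series" means these compounds.

Measured in an ADME assay on the whole organism (strain Sprague-Dawley) for pharmacokinetics, with Rattus norvegicus as the target, read by LC-MS, at a dose of 25 mg/kg by the oral route; a lower number here means that a smaller share of the oral dose reaches the circulation, a higher number that a larger share of the oral dose reaches the circulation:
- compound 2, `C=CC(=O)N1CC[C@H](N2C(=O)N(c3ccccc3)Cc3cnc(Nc4ccc(N5CCN(C)CC5)cc4)nc32)C1`: 54%
- compound 3, `C=CC(=O)N1CC[C@H](N2C(=O)N(c3ccccc3)Cc3cnc(Nc4ccccc4)nc32)C1`: 44%
- compound 1, `C=CC(=O)N1CC[C@H](N2C(=O)N(Cc3ccccc3)Cc3cnc(Nc4ccc(N5CCN(C)CC5)cc4OC)nc32)C1`: 24%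

Compound 2 stands at the top of these three numbers, but its gap to compound 3 is within the scatter; only compound 1 lies clearly lower, and compound 1 differs from compound 2 in two places at once, so its value alone cannot be tied to either change. Compound 4, `C=CC(=O)N1CC[C@H](N2C(=O)N(c3ccccc3)Cc3cnc(Nc4ccc(N5CCN(C)CC5)c(OC)c4)nc32)C1`, is compound 2 with methoxy in place of hydrogen on an aromatic carbon, the new group sitting ortho to the 4-methylpiperazin-1-yl group and meta to a large group. Within the data shown here, the one single-point step measured here, a number 10 percentage points lower from compound 2 to compound 3 (within the scatter), concerns a different group and a different position and shows no movement beyond the scatter. Nothing measured here speaks directly to a methoxy at this position. Among the measured compounds shown here, compound 4 is therefore expected to stay close to compound 2, with a step of about a number 9 percentage points lower from compound 2 to compound 4 (within the scatter) in this assay, leaning slightly lower only because compound 1, the sole methoxy-bearing compound, gives 24%. Compound 4 is estimated at 45%, in the range 25% to 65%.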

Compound 4, oral bioavailability: 20%
Beside the measured number, compound 4's estimate is 25 percentage points above it, outside the stated range (below it).
By their numbers in this assay, from the lowest: compounds 4 and 1 (each within the scatter of the next); then compounds 3 and 2 (each within the scatter of the next).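

In this assay, among these compounds, the aromatic carbon ortho to the 4-methylpiperazin-1-yl group proves sensitive to substitution: methoxy in place of hydrogen there gives a number 34 percentage points lower from compound 2 to compound 4 (beyond the scatter), whereas the only earlier single-place step, a number 10 percentage points lower from compound 2 to compound 3 (within the scatter), showed no movement beyond the scatter. The earlier compounds shown here could not reveal this, since compound 1 also carries a methoxy but differs from compound 2 in two places, so its value could not be tied to that group. Nothing available gives a measured reason for the drop.

The compounds shown leave open whether a fluorine, a methyl or a hydroxyl group at this position would lower the number as methoxy does. They also leave open whether methoxy at this carbon would have the same effect without the 4-methylpiperazin-1-yl group.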